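A few compounds are considered here, and "the series" means these few. Any claim that something is new, unique, unknown or untested is made for them only; others in the source may bear on it.

Compound 1: `COC(=O)c1scc(-c2ccc(NC(=O)c3ccccn3)cc2)c1OC` — 19200 nM
Compound 2: `COC(=O)c1scc(-c2ccc(NC(=O)c3cccc(C(F)(F)F)c3)cc2)c1OC` — 26200 nM

Both compounds were tested in a functional assay on MCF7 cells (Homo sapiens) for antiproliferative activity, read by MTT assay, with a stated time of 24 h (a higher number here means a weaker inhibitor, a lower number a stronger inhibitor), and both inhibit only weakly. Going by the values given here, compound 2 has the higher of the two numbers, yet its only neighbour, compound 1, sits within the scatter of it: the single measured step, a 1.4-fold higher number from compound 1 to compound 2 (0.14 log units; within the scatter), exchanges the whole ring attached to the carbonyl carbon and leaves the read-out essentially unchanged.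

Compound 3, `COC(=O)c1scc(-c2ccc(NC(=O)c3cccc(I)c3)cc2)c1OC`, has not yet been measured. It differs from compound 2 in one place: iodo in place of trifluoromethyl on an aromatic carbon. Among the compounds with values here, no measured step exchanges one substituent for another on this ring, so the one step that exists bears on it only loosely, and that step was within the scatter. With nothing in the data pointing either way, the step from compound 2 to compound 3 in this assay is expected to be a 1.1-fold lower number from compound 2 to compound 3 (0.06 log units; within the scatter), that is, no change beyond the scatter. Compound 3 is therefore estimated at 23000 nM, with a range from 9000 nM to 58000 nM.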

Compound 3, half-maximal inhibitory concentration: 12300 nM
For compound 3 the middle estimate is 1.9-fold (0.27 log units) above the measured one; the measured number falls inside the stated range.
By their numbers in this assay, from the lowest: compounds 3, 1 and 2 (each within the scatter of the next, the first and the last beyond it).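

In this assay, exchanging trifluoromethyl for iodo gives a 2.1-fold lower number from compound 2 to compound 3 (0.33 log units; beyond the scatter). Going by these compounds alone, this is the first measured change of a single substituent on this ring with the ring itself kept, and it shows that the group at this place can move the read-out beyond the scatter, though only modestly. Exchanging the whole ring gives a different picture, since 3-iodophenyl in place of pyridin-2-yl gives a 1.6-fold lower number from compound 1 to compound 3 (0.19 log units; within the scatter), so neither whole-ring step separates from the scatter, while the single-substituent step does so only narrowly. Nothing among the available data offers an explanation for the difference between trifluoromethyl and iodo.

Going by these compounds, this rests on a single pair of compounds, so it remains open whether the step reflects something particular to iodo or whether chloro, bromo, an amine or a carboxylic acid at the same place would read alike. On these data alone, it is also open whether the same exchange would give a similar step on the pyridine-free ring at another place, or in any assay other than this assay.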